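A few compounds are considered here, and "the series" means these few. Any claim that something is new, unique, unknown or untested is made for them only; others in the source may bear on it.

Compound 2 `Cc1cc(C)c(CN2CCc3c(Cl)cc([C@H](CO)[C@H]4CCCO4)c(Cl)c3C2=O)c(=O)[nH]1` is the point of departure. Among the measured compounds shown here, in an assay on cells for inhibition of histone-lysine N-methyltransferase EZH2 (Homo sapiens), read by ELISA, with a stated time of 72 h (on this read-out higher numbers stand for weaker inhibition and lower numbers for stronger inhibition), compound 2 gives 40 nM, the only number it has; two further entries for it return no single number. Two other compounds of the shared core give a sense of how widely repeated readings can fall. Compound 1 `COC(c1cc(Cl)c2c(c1Cl)C(=O)N(Cc1c(C)cc(C)[nH]c1=O)CC2)C1CCOCC1` has in this assay the values 1460 nM; 9 nM (2 entries), and compound 3 `COC(c1cc(Cl)c2c(c1Cl)C(=O)N(Cc1c(C)cc(C)[nH]c1=O)CC2)C1CCS(=O)(=O)CC1` has 430 nM; 18 nM (2 entries); both sets, as the several entries of compound 1 in this assay, 1460 nM; 9 nM (2 entries) and the several entries of compound 3 in this assay, 430 nM; 18 nM (2 entries) show, span far more than the usual scatter, so any single reading of this series is read with caution.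

Compound 4 `Cc1cc(C)c(CN2CCc3c(Cl)cc([C@@H](CO)[C@@H]4CCOC4)c(Cl)c3C2=O)c(=O)[nH]1` has not yet been measured. It keeps the same atoms as compound 2 but joins them differently: a group of 8 heavy atoms (6 carbon, 2 oxygen; one five-membered non-aromatic ring with 1 hetero atom) in place of a group of 8 heavy atoms (6 carbon, 2 oxygen; one five-membered non-aromatic ring with 1 hetero atom), on an aromatic carbon. The group that leaves and the group that enters are matched in size and in count of donors and acceptors, and the change sits on an aromatic carbon of a six-membered aromatic ring of carbon only, part of a fused system of two rings.

With no pair of measured compounds differing in one place, no step is shown for comparison. The expected step of a 1.3-fold higher number from compound 2 to compound 4 (0.10 log units; within the scatter) is therefore no larger than the scatter, in either direction. Compound 4 is thus expected to give about 50 nM, within a range from 15 nM to 170 nM.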

Compound 4, half-maximal inhibitory concentration: 2910 nM
For compound 4 the middle estimate is 58-fold (1.76 log units) below the measured one; the measured number lies above the stated range.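

On this aromatic carbon, ortho to a chloro group, a group of the same atoms joined differently gives in this assay a 73-fold higher number from compound 2 to compound 4 (1.86 log units; beyond the scatter). Among the compounds shown here, the read-out here therefore responds to how the atoms of the group are joined and not only to their number or to the count of donors and acceptors, which the earlier compounds could not show, as no measured pair among them differed in one place. The step is printed as beyond the scatter, but it rests on one number at each end, and repeated readings of other compounds of the shared core have spread widely: the several entries of compound 1 in this assay, 1460 nM; 9 nM (2 entries); (the several entries of compound 3 in this assay, 430 nM; 18 nM (2 entries)).

The compounds shown leave open how much of the step belongs to the point at which the five-membered non-aromatic ring is joined and how much to the two defined stereocentres, since the two groups differ in their joining and no compound separates these features. Also open, as far as these compounds go, is how this aromatic carbon would read with an amine, a carboxylic acid or a longer chain in the group.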